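Branched cyclohexyl chain replacing pentyl on the urea nitrogen

The source may hold more compounds than are shown below. What is called first, only, known or untested is meant among the compounds shown, and "the series" means these compounds.

Measured so far:
Compound 1, `Cc1nc(N)sc1CCCN/C(N)=N/C(=O)NCC(C)CCc1ccccc1`: 63.1 nM
Compound 2, `Cc1nc(N)sc1CCCN/C(N)=N/C(=O)NCc1ccco1`: 10.5 nM
Compound 3, `CCCCCCNC(=O)/N=C(\N)NCCCc1sc(N)nc1C`: 28.8 nM

All three share one core and differ only in the group carried on a saturated chain carbon bound to an amide-type nitrogen. In an assay on membranes from Sf9 cells for displacement of a labelled ligand from histamine H2 receptor (Homo sapiens), read by scintillation counting, with a stated time of 60 min (a lower number here means a stronger inhibitor, a higher number a weaker inhibitor), compound 2 gives 10.5 nM, compound 3 gives 28.8 nM and compound 1 gives 63.1 nM. Compound 3 therefore stands second highest of the three numbers, with compound 1 nearest and compound 2 furthest away.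

Compound 4, `Cc1nc(N)sc1CCCN/C(N)=N/C(=O)NCC(C)CC1CCCCC1`, is not yet measured. It differs from compound 3 in one place: 1-(cyclohexylmethyl)ethyl in place of pentyl on a saturated chain carbon bound to an amide-type nitrogen.

Among the measured compounds shown here, only one measured step touches this position, a 2.7-fold higher number from compound 2 to compound 3 (0.44 log units; beyond the scatter), which shows that exchanging the group here moves the number modestly. For the measured compounds named here, no step is recorded between compound 3 and compound 1, but their two values show that a branched chain ending in a ring gives a somewhat higher number than pentyl. Compound 4 carries such a branched chain, closer in shape to compound 1 than to compound 3, so a small rise is expected, possibly within the scatter.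

Compound 4 is estimated at 42 nM, within 15 nM to 120 nM, an expected step of a 1.5-fold higher number from compound 3 to compound 4 (0.16 log units; within the scatter).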

Compound 4, inhibition constant: 70.8 nM
The estimate for compound 4 lay 1.7-fold (0.23 log units) below the measured number; the measured number falls inside the stated range.
By their numbers in this assay, from the lowest: compound 2; then compound 3; then compounds 1 and 4 (each within the scatter of the next).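

Putting 1-(cyclohexylmethyl)ethyl in place of pentyl gives, in this assay, a 2.5-fold higher number from compound 3 to compound 4 (0.39 log units; beyond the scatter), so this larger group with its six-membered non-aromatic ring does not hold the number seen with pentyl. Against the furan-2-yl group the change is wider, a 6.7-fold higher number from compound 2 to compound 4 (0.83 log units; beyond the scatter), the largest step listed at this position so far. Cyclohexyl in place of benzyl on a saturated chain carbon, three bonds along the chain from an amide-type nitrogen, gives a 1.1-fold higher number from compound 1 to compound 4 (0.05 log units; within the scatter), so in this assay these two ring-bearing groups cannot be told apart, which is the first direct comparison of a non-aromatic end group with an aromatic one on this branched chain.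

No other measurement bears on why the number shifts with these groups. Also open, going by these compounds, is whether the branch or the ring accounts for the step from pentyl, which a straight chain ending in cyclohexyl would separate, and whether an amine or a carboxylic acid at the end of the chain would bring the number closer to that of compound 2.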